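A few compounds are considered here, and "the series" means these few. Any claim that something is new, unique, unknown or untested is made for them only; others in the source may bear on it.

Compound 1 `COc1ccc(-c2cc(/C=C/C(=O)c3ccc(C)cc3)nc3cc(-c4ccccc4)nn23)cc1OC` belongs to a small set of three chalcone-bearing analogues that share one core and differ in the pattern of methoxy groups on the aryl rings. In a functional assay on A549 cells (Homo sapiens) for antiproliferative activity, read by MTT assay, with a stated time of 24 h (a lower number here means a stronger inhibitor, a higher number a weaker inhibitor), compound 1 gives 17200 nM. For the measured compounds named here, compound 2 `COc1cc(-c2cc(/C=C/C(=O)c3ccc(C)cc3)nc3cc(-c4ccccc4)nn23)cc(OC)c1OC` gives 19400 nM, and compound 3 `COc1ccc(/C=C/C(=O)c2cc(-c3cc(OC)c(OC)c(OC)c3)n3nc(-c4ccccc4)cc3n2)cc1OC` gives 20500 nM; the three numbers sit close together, and the only single-change step among them, a 1.1-fold higher number from compound 1 to compound 2 (0.05 log units; within the scatter), stays within the scatter. Going by the values given here, no step has been computed between compound 1 and compound 3, and their two values simply lie near each other.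

Compound 4 `COc1ccc(-c2cc(/C=C/C(=O)c3ccccc3)nc3cc(-c4ccccc4)nn23)cc1OC` has not been measured in this assay. It differs from compound 1 by hydrogen in place of methyl on an aromatic carbon. Among the compounds with values here, none of the measured steps touches this ketone-side aryl ring, so the only guide is the observation that a change of one aromatic substituent, in the step from compound 1 to compound 2, moved the number hardly at all. The step from compound 1 to compound 4 is therefore expected to be a 1.1-fold higher number from compound 1 to compound 4 (0.04 log units; within the scatter), with no direction that can be told from the data. Compound 4 is estimated at 19000 nM, in a range from 9000 nM to 40000 nM.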

Compound 4, half-maximal inhibitory concentration: 10700 nM
Beside the measured number, compound 4's estimate is 1.8-fold (0.25 log units) above it, and the stated range covers the measured number.
By their numbers in this assay, from the lowest: compounds 4, 1, 2 and 3 (each within the scatter of the next).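

For the compounds shown here, this is the first look at the 4-methylphenyl ring on the ketone side, which the earlier compounds left unchanged. In this assay, removing the methyl para to a large group gives a 1.6-fold lower number from compound 1 to compound 4 (0.21 log units; within the scatter), so the step stays within the scatter and compound 4, with a plain phenyl, remains in the same range as compound 1 without this methyl. No measurement is available that would explain this step.

A single replacement by hydrogen says little about how this position responds to other groups, so an amine, a carboxylic acid or a longer chain in place of the methyl could behave quite differently. As far as these compounds go, whether any substituent on this ring can move the number beyond the scatter remains open.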